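Swapping the Imidazole Tail for a Pyrrole on the Imide

The compounds below may be only part of what the source reports. "The series", "measured", "known", "first", "only" and "open" are said of these compounds alone.

Compound 1 `Cn1cc(C2=C(c3nn(CCn4ccnc4)c4ncccc34)C(=O)NC2=O)c2ccccc21` carries an unsubstituted imide and a chain ending in an imidazole. In a functional assay on K562 cells (Homo sapiens) for antiproliferative activity, read by MTT assay, with a stated time of 48 h (a lower number here means a stronger inhibitor, a higher number a weaker inhibitor), compound 1 gives > 100000 nM, which is a limit of the assay rather than a number. Compound 2 `COc1ccc(N2C(=O)C(c3cn(C)c4ccccc34)=C(c3nn(CCCN4CCCCC4)c4ncccc34)C2=O)cc1` also stops at a limit, giving > 100000 nM in this assay. Going by the values given here, compound 3 `Cn1cc(C2=C(c3nn(CCCCn4ccnc4)c4ncccc34)C(=O)N(c3ccccc3)C2=O)c2ccccc21`, with a phenyl on the imide and a longer chain to the imidazole, is the one compound with a measured number, 5030 nM in this assay. Compound 1 thus stands at the weak end of what has been measured, sitting at the limit of > 100000 nM in this assay, at which 2 of the 3 values shown sit.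

Compound 4 `Cn1cc(C2=C(c3nn(CCCn4cccc4)c4ncccc34)C(=O)NC2=O)c2ccccc21` differs from compound 1 by (1H-pyrrol-1-yl)methyl in place of 1H-imidazol-1-yl on a saturated chain carbon, two bonds along the chain from an aromatic nitrogen. Among the compounds with values here, no step between measured compounds isolates this change, so the size of its effect is not known from these data. With compound 1 fixed only at a limit, any step can be estimated only loosely; a modest shift in either direction, or none beyond the scatter, is the expectation. The step from compound 1 to compound 4 is estimated at an at least 1.6-fold lower number from compound 1 to compound 4 (0.22 log units; that floor lies within the scatter). Compound 4 is expected to give about 60000 nM, within a range from 15000 nM to 300000 nM, with a fair chance that it too is reported only as a limit.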

Compound 4, half-maximal inhibitory concentration: 21600 nM
Estimate against measurement, compound 4: 2.8-fold (0.44 log units) above; measured number inside the range.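

In this assay, going by these compounds alone, moving from the imidazole tail to the pyrrole tail on the unsubstituted imide gives an at least 4.6-fold lower number from compound 1 to compound 4 (0.66 log units; beyond the scatter), the first step in this set that can be read at this position on the chain. With the imide hydrogen kept, compound 4 gives a measured number, 21600 nM. Among the compounds shown, then, an unsubstituted imide does not by itself rule out a measured number. The step is a floor and not a size, as compound 1 has only a limit for its value: the limit of > 100000 nM in this assay, at which 2 of the 4 values shown sit.

The change also brings two things at once, since 1H-imidazol-1-yl leaves and (1H-pyrrol-1-yl)methyl enters, so the compounds shown do not tell whether the pyrrole ring or the extra chain carbon accounts for the step. Going by these compounds, a 3-(1H-imidazol-1-yl)propyl chain or a 2-(1H-pyrrol-1-yl)ethyl chain on the same unsubstituted imide would separate the two, and whether a phenyl on the imide adds to the pyrrole tail also stays open.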